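The source may hold more compounds than are shown below. What is called first, only, known or untested is meant among the compounds shown, and "the series" means these compounds.

Working notes, compound 1 to compound 3.

Within the data shown here, compound 1 `C#CCNC1CCc2c(SCCc3cccc(C)c3)cccc21` is one of two compounds so far measured in an ADME assay on isolated protein for inhibition of Amine oxidase [flavin-containing] B (Homo sapiens); a lower number here means a stronger inhibitor, a higher number a weaker inhibitor. In this assay compound 1 gives 4960 nM, the higher of the two numbers. The other compound, compound 2 `C#CCNC1CCc2c(SCc3ccc(C)cc3)cccc21`, gives 320 nM, and the gap between the two lies beyond the usual scatter of repeated measurements; the two differ in several places at once, so nothing is drawn from that pair about any single change.

Compound 3 `C#CCNC1CCc2c(SCCc3cccc(OC)c3)cccc21` has not been measured. It differs from compound 1 in one place: methoxy in place of methyl on an aromatic carbon. Cut one bond further out, the change reads 3-methylphenyl to 3-methoxyphenyl. Among the measured compounds shown here, no measured pair in this set shows this exchange, so no step is at hand to lean on. With nothing to set a direction, the expected step from compound 1 to compound 3 in this assay is a 1.0-fold higher number from compound 1 to compound 3 (0.00 log units; within the scatter), not beyond the scatter. For compound 3 the estimated value in this assay is 5000 nM, with a range from 1500 nM to 16000 nM.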

Compound 3, half-maximal inhibitory concentration: 3820 nM
Estimate against measurement, compound 3: 1.3-fold (0.12 log units) above, within the range that was stated.
By their numbers in this assay, from the lowest: compound 2; then compounds 3 and 1 (each within the scatter of the next).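

Among these compounds, the exchange of 3-methylphenyl for 3-methoxyphenyl gives the first single-place step: in this assay it is a 1.3-fold lower number from compound 1 to compound 3 (0.11 log units; within the scatter). At this position on the aromatic ring, therefore, methoxy and methyl cannot be told apart by this read-out, even though methoxy brings one more heavy atom and a hydrogen-bond acceptor. No supporting measurement bears on this result.

Open, as far as these compounds go, is whether an amine, a carboxylic acid or a chloro group on the same aromatic carbon would also stay within the scatter of compound 1. Also open is which of the several differences between compound 1 and compound 2 accounts for the gap between their numbers.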